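Microsomal stability of the shared core: step to compound 3

This account rests on a few compounds, and the source may have more. Where it says the series, first, only, none or still open, it means among the compounds named here.

compound 1 `COc1ccc(Nc2ncc3ccc(-c4ccccc4OC)n3n2)cc1` — 0.117 h
compound 2 `COc1ccccc1-c1ccc2cnc(Nc3ccc(S(=O)(=O)N(C)C)cc3)nn12` — 0.0833 h

In an in vitro ADME assay on microsomes from liver (Homo sapiens) for metabolic stability, using NADPH, with a stated time of 10 min, tested at 0.5 uM (on this read-out higher numbers stand for a longer-lived compound and lower numbers for a shorter-lived compound), compound 1 gives 0.117 h and compound 2 gives 0.0833 h. Compound 2 and compound 1 lie within the scatter of each other: a 1.4-fold lower number from compound 1 to compound 2 (0.15 log units; within the scatter). Both carry the same core; they differ only in the group para to the large group.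

Compound 3 `COc1ccccc1-c1ccc2cnc(Nc3ccc(N4CCN(C[C@H](C)O)CC4)cc3)nn12` differs from compound 2 at that same position: 4-(2-hydroxypropyl)piperazin-1-yl in place of dimethylsulfamoyl on an aromatic carbon. Among the measured compounds shown here, the only measured step that bears on this place, from compound 1 to compound 2, exchanged one substituent for another there without a move beyond the scatter. No measured compound carries a piperazinyl group, so nothing shown speaks to what this larger, hydroxyl-bearing group does in this assay. On the evidence of compound 2 and the step already seen, no step beyond the scatter is expected, so for compound 3 the estimate is a 1.1-fold higher number from compound 2 to compound 3 (0.03 log units; within the scatter). Compound 3 is therefore expected to give about 0.09 h, with a range from 0.04 h to 0.2 h.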

Compound 3, half-life: > 0.666 h
Compound 3 ended at the assay's limit (the forecaster's own chance of this, stated with the estimate: 5%); middle value at least 7.4-fold (0.86 log units) from the limit.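

The position para to a large group is not silent in this assay: 4-(2-hydroxypropyl)piperazin-1-yl in place of dimethylsulfamoyl gives an at least 7.9-fold higher number from compound 2 to compound 3 (0.90 log units; beyond the scatter), whereas the earlier exchange at this place stayed within the scatter. With methoxy as the group replaced, the same change gives an at least 5.6-fold higher number from compound 1 to compound 3 (0.75 log units; beyond the scatter), so the rise appears against both earlier substituents. Compound 3 sits at a limit of the assay, not at a number: the limit of > 0.666 h in this assay, at which 1 of the 3 values shown sits.

The entering group brings a six-membered non-aromatic ring and a hydroxyl-bearing chain together, and the compounds shown do not separate their shares in the step. Going by these compounds, whether an unsubstituted piperazine, a morpholine ring or the opposite stereocentre in the 2-hydroxypropyl chain would give the same result stays open, as does how far past its limit compound 3 lies.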